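This account rests on a few compounds, and the source may have more. Where it says the series, first, only, none or still open, it means among the compounds named here.

- compound 1 `Cc1ccsc1-c1cc(-c2ccc(Cl)o2)cc(-c2ccco2)n1`: 10600 nM
- compound 2 `Cc1ccsc1-c1cc(-c2ccc(Cl)o2)cc(-c2ccc(Cl)cc2)n1`: 15600 nM

In a functional assay on K562 cells (Homo sapiens) for cytotoxicity, read by ELISA, with a stated time of 4 days (on this read-out higher numbers stand for weaker inhibition and lower numbers for stronger inhibition), compound 2 gives 15600 nM, which lies within the scatter of compound 1 at 10600 nM. Compound 3 `Cc1ccsc1-c1cc(-c2ccc(Cl)o2)cc(-c2cccnc2)n1` has pyridin-3-yl in place of 4-chlorophenyl on an aromatic carbon next to the ring nitrogen (pyridin-3-yl in place of 4-chlorophenyl on an aromatic carbon). For the measured compounds named here, the only measured step at that carbon is a 1.5-fold higher number from compound 1 to compound 2 (0.17 log units; within the scatter), with 4-chlorophenyl in place of furan-2-yl. Going by the values given here, that single small step is the sole guide, so no change beyond the scatter is expected in this assay. The estimate is an expected 1.2-fold lower number from compound 2 to compound 3 (0.08 log units; within the scatter). For compound 3 the expected value is 13000 nM, with an estimated range of 5000 nM to 30000 nM.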

Compound 3, half-maximal inhibitory concentration: 12300 nM
The estimate for compound 3 lay 1.1-fold (0.02 log units) above the measured number, within the range that was stated.
By their numbers in this assay, from the lowest: compounds 1, 3 and 2 (each within the scatter of the next).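

In this assay, replacing 4-chlorophenyl with pyridin-3-yl gives a 1.3-fold lower number from compound 2 to compound 3 (0.10 log units; within the scatter), and replacing furan-2-yl with it gives a 1.2-fold higher number from compound 1 to compound 3 (0.06 log units; within the scatter). This carbon next to the ring nitrogen therefore now carries three different aromatic rings, including one with a hydrogen-bond acceptor, without any step beyond the scatter. Nothing measured explains why these numbers sit so close together. The compounds shown leave open whether an amine, a carboxylic acid or a longer chain on this carbon would give a step beyond the scatter.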